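Hydroxy for methyl on the ring nitrogen of compound 2

The source may hold more compounds than are shown below. What is called first, only, known or untested is meant among the compounds shown, and "the series" means these compounds.

Measured compounds:
compound 1, `Cc1cc(=O)c(O)c(C(=O)O)[nH]1`, 24% in an assay for inhibition of arginase-1 (Homo sapiens), read by scintillation counting, with a stated time of 5 min, tested at 200 uM; on this read-out higher numbers stand for more inhibition at the one concentration tested (going by the name of the read-out) and lower numbers for less inhibition
compound 2, `Cc1cc(=O)c(O)c(C(=O)O)n1C`, 2% in this assay

Compound 2 stands lowest of the two numbers shown in this assay; its nearest neighbour is compound 1, whose value lies higher by a step beyond the scatter. That single step, a number 22 percentage points lower from compound 1 to compound 2 (beyond the scatter), describes methyl in place of hydrogen on the aromatic nitrogen and is the only one that bears on the next change. Compound 3, `Cc1cc(=O)c(O)c(C(=O)O)n1O`, differs from compound 2 by hydroxy in place of methyl on an aromatic nitrogen. The substituent leaving is the same methyl whose entry cost inhibition in the measured step, so the return of a hydrogen-bond donor at that position is expected to restore some of it. Compound 3 is therefore estimated at 22%, with a range from 0% to 55%, a step of a number 20 percentage points higher from compound 2 to compound 3 (beyond the scatter) upward.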

Compound 3, a percentage reported as inhibition, at one concentration (the size of the read-out at that concentration, not a potency): 12%
Compound 3: middle estimate off by 10 percentage points, on the high side; the measured number falls inside the stated range.
By their numbers in this assay, from the lowest: compounds 2 and 3 (each within the scatter of the next); then compound 1.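

On the aromatic nitrogen, in this assay, hydroxy and methyl are not told apart: the change gives a number 10 percentage points higher from compound 2 to compound 3 (within the scatter), even though hydroxy brings a hydrogen-bond donor that methyl lacks. Hydrogen on the same nitrogen is told apart from hydroxy, with a number 12 percentage points lower from compound 1 to compound 3 (beyond the scatter), so neither of the two substituents shown there matches the unsubstituted nitrogen of compound 1 on this read-out. Nothing available explains this result. The compounds shown leave open whether an amino or methoxy group on that nitrogen, or a longer chain such as ethyl, would also stay apart from compound 1. They also leave open whether the same order would hold if an amide stood in place of the carboxy group.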